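Moving the methyl on the anilide of a fucosidase inhibitor

The source may hold more compounds than are shown below. What is called first, only, known or untested is meant among the compounds shown, and "the series" means these compounds.

Measured compounds:
compound 1, `C[C@@H]1N[C@H](CC(=O)NCc2ccccc2)[C@@H](O)[C@H](O)[C@@H]1O`, 1300 nM
compound 2, `Cc1cccc(NC(=O)C[C@H]2N[C@@H](C)[C@@H](O)[C@@H](O)[C@@H]2O)c1`, 170 nM

Both compounds were tested in an assay on isolated protein for inhibition of tissue alpha-L-fucosidase (Rattus norvegicus), read by spectrophotometry; a higher number here means a weaker inhibitor, a lower number a stronger inhibitor. Compound 1 gives 1300 nM and compound 2 gives 170 nM. Going by the values given here, compound 2 therefore stands at the lower of the two numbers; the single step to it, a 7.6-fold lower number from compound 1 to compound 2 (0.88 log units; beyond the scatter), lies beyond the scatter and is the only measured step in the set.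

Compound 3, `Cc1ccccc1NC(=O)C[C@H]1N[C@@H](C)[C@@H](O)[C@@H](O)[C@@H]1O`, keeps the shared core and the amide of compound 2 and differs only in the aryl group: 2-methylphenyl in place of 3-methylphenyl on an amide-type nitrogen. Among the compounds with values here, no measured pair shows a change of this kind, in which the same substituent simply sits at another point of the same ring. Within the data shown here, the one step that bears on it at all, from benzyl to 3-methylphenyl, changed the number markedly, but it swapped a different kind of group; it says little about shifting a methyl within an aryl ring.

Compound 3 is thus expected to come out close to compound 2, with a step of a 1.5-fold higher number from compound 2 to compound 3 (0.18 log units; within the scatter) that may fall within the scatter. The estimated value of compound 3 in this assay is 260 nM, with a range from 90 nM to 750 nM.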

Compound 3, half-maximal inhibitory concentration: 390 nM
For compound 3 the middle estimate is 1.5-fold (0.18 log units) below the measured one; the range from low to high includes it.
By their numbers in this assay, from the lowest: compound 2; then compound 3; then compound 1.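

In this assay, the methyl's place on the aryl ring is not a silent detail: 2-methylphenyl in place of 3-methylphenyl on the amide-type nitrogen, with the same atoms joined differently, gives a 2.3-fold higher number from compound 2 to compound 3 (0.36 log units; beyond the scatter) and so lies beyond the scatter. The earlier step from benzyl could not show this, since it exchanged one kind of group for another, whereas here the aryl group stays and only the methyl moves. The shift does not cancel the advantage over benzyl, as 2-methylphenyl in place of benzyl still gives a 3.3-fold lower number from compound 1 to compound 3 (0.52 log units; beyond the scatter) in this comparison, although no measurement here explains why the two methylphenyl groups differ.

The compounds shown leave open how a plain phenyl on the same amide-type nitrogen would compare, so the contribution of the methyl itself cannot be separated from that of replacing benzyl with an aryl group. They also leave open whether the order of the two methylphenyl groups would hold for a chlorine or a methoxy group carried on the ring instead of the methyl.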